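Amide nitrogen substituent swap on the shared core

This account rests on a few compounds, and the source may have more. Where it says the series, first, only, none or still open, it means among the compounds named here.

Compound 2 `CCn1c(C(=O)Nc2cccc(C(F)(F)F)c2)ccc1C(CC)(CC)c1ccc(OCCC(O)(CC)CC)c(C)c1` carries a 3-(trifluoromethyl)phenyl on the amide-type nitrogen. In a functional assay on Caco-2 cells (Homo sapiens) for antiproliferative activity, read by MTT assay, with a stated time of 48 h (a lower number here means a stronger inhibitor, a higher number a weaker inhibitor), compound 2 gives only a limit, > 50000 nM, so its number is not pinned down. For the measured compounds named here, the one measured step leads to it from compound 1 `CCn1c(C(=O)NCCN)ccc1C(CC)(CC)c1ccc(OCCC(O)(CC)CC)c(C)c1`, which in this assay gives 1740 nM: an at least 28-fold higher number from compound 1 to compound 2 (1.45 log units; beyond the scatter), with compound 2 resting at the limit of > 50000 nM in this assay, at which 1 of the 2 values shown sits.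

Compound 3 `CCC(C)C(CO)NC(=O)c1ccc(C(CC)(CC)c2ccc(OCCC(O)(CC)CC)c(C)c2)n1CC` differs from compound 2 by 1-(hydroxymethyl)-2-methylbutyl in place of 3-(trifluoromethyl)phenyl on an amide-type nitrogen. Going by the values given here, only the step from compound 1 to compound 2 bears on this change; it exchanged a chain with no ring and a donor for the aryl group that now leaves, and was large. The change to compound 3 runs the other way, toward a chain with no ring carrying one donor and one acceptor, so a lowering step in this assay is expected, though not necessarily back to the level of compound 1. The step from compound 2 to compound 3 is estimated at an at least 6.2-fold lower number from compound 2 to compound 3 (0.79 log units; beyond the scatter). Compound 3 is expected at 8000 nM, in a range from 2000 nM to 40000 nM.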

Compound 3, half-maximal inhibitory concentration: > 50000 nM
Compound 3 gave a limit, no number (the forecaster's own chance of this, stated with the estimate: 30%); middle value at least 6.2-fold (0.79 log units) away from the limit.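

In this assay compound 3 gives > 50000 nM, which is a limit of the assay and not a number. The step of an at least 28-fold higher number from compound 1 to compound 3 (1.45 log units; beyond the scatter) shows that a large move to a higher number does not depend on an aryl group on the amide-type nitrogen: 1-(hydroxymethyl)-2-methylbutyl, with no ring, goes the same way as 3-(trifluoromethyl)phenyl, leaving 2-aminoethyl as the only group shown here with a measured number. The step between compound 2 and compound 3 cannot be read, so the two groups cannot be ordered, and little of this position is resolved: the limit of > 50000 nM in this assay, at which 2 of the 3 values shown sit.

Whether the amine of 2-aminoethyl or its short chain accounts for the value of compound 1 stays open. From the compounds shown here alone, how a 3-aminopropyl, 2-hydroxyethyl or 2-carboxyethyl chain on this nitrogen would read is also open.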